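From (ethylamino)methyl to carbamoyl: foreseeing compound 4

The compounds below may be only part of what the source reports. "The series", "measured", "known", "first", "only" and "open" are said of these compounds alone.

Compound 2 `CCNCc1cc(-c2c(C(=O)NCC)noc2-c2cc(C(C)C)c(O)cc2O)on1` gives 45 nM in a functional assay on HCT-116 cells (Homo sapiens) for inhibition (a higher number here means a weaker inhibitor, a lower number a stronger inhibitor), the lowest of the three numbers in hand. Compound 3 `CCNC(=O)c1noc(-c2cc(C(C)C)c(O)cc2O)c1-c1cc(CN2CCCC2)no1` gives 51 nM, and the step of a 1.1-fold higher number from compound 2 to compound 3 (0.05 log units; within the scatter) is within the scatter, so neither can be called the stronger. Compound 1 `CCNC(=O)c1noc(-c2cc(C(C)C)c(O)cc2O)c1-c1cc(COCC(=O)OC)no1` gives 262 nM; the steps of a 5.8-fold lower number from compound 1 to compound 2 (0.77 log units; beyond the scatter) and a 5.1-fold lower number from compound 1 to compound 3 (0.71 log units; beyond the scatter) both lie beyond the scatter.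

Compound 4 `CCNC(=O)c1noc(-c2cc(C(C)C)c(O)cc2O)c1-c1cc(C(N)=O)no1` differs from compound 2 in one place: carbamoyl in place of (ethylamino)methyl on an aromatic carbon. Among the compounds with values here, no measured step exchanges this group for a carbamoyl, so the bearing of the data is indirect. The two steps from compound 1 show that ethylamino or pyrrolidin-1-yl in place of (methoxycarbonyl)methoxy gave modest steps downward; compound 4 keeps neither of those groups and instead carries a carbamoyl with a double bond outside aromatic rings. For compound 4 the expected step is therefore upward, a 3.3-fold higher number from compound 2 to compound 4 (0.52 log units; beyond the scatter), leaving the number between those of compound 1 and compound 2. The estimate for compound 4 is 150 nM, with a range from 60 nM to 400 nM.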

Compound 4, half-maximal inhibitory concentration: 79 nM
Estimate against measurement, compound 4: 1.9-fold (0.28 log units) above; low and high end bracket the measured number.
By their numbers in this assay, from the lowest: compounds 2, 3 and 4 (each within the scatter of the next); then compound 1.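

In this assay the carbamoyl group on this aromatic carbon stands level with both amine-bearing side chains: a 1.8-fold higher number from compound 2 to compound 4 (0.24 log units; within the scatter) and a 1.5-fold higher number from compound 3 to compound 4 (0.19 log units; within the scatter) are each within the scatter. Against the ester-bearing side chain, a 3.3-fold lower number from compound 1 to compound 4 (0.52 log units; beyond the scatter) lies beyond the scatter. The steps of a 5.8-fold lower number from compound 1 to compound 2 (0.77 log units; beyond the scatter) and a 5.1-fold lower number from compound 1 to compound 3 (0.71 log units; beyond the scatter) point the same way. Among these four compounds, then, the lower number relative to compound 1 does not require an ethylamino or pyrrolidin-1-yl group, as compound 4 carries neither. Nothing at hand accounts for this result.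

From the compounds shown here alone, it remains open how a carboxylic acid, a simple aminomethyl group or an N-ethyl carbamoyl at this place would compare with compound 4. Whether the level shared by compound 2, compound 3 and compound 4 holds on other cell lines also stays unanswered.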